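An iodo group on the phenyl of compound 2

This account rests on a few compounds, and the source may have more. Where it says the series, first, only, none or still open, it means among the compounds named here.

In a functional assay on MDA-MB-231 cells (Homo sapiens) for antiproliferative activity, read by sulforhodamine B assay, with a stated time of 48 h (on this read-out lower numbers stand for stronger inhibition of growth and higher numbers for weaker inhibition of growth), compound 1 (`O=C(NNC(=S)Nc1ccccc1)C1=C(Cl)c2ccccc2CCC1`) gives 2460 nM and compound 2 (`ClC1=C(c2nnc(-c3ccccc3)o2)CCCc2ccccc21`) gives 1970 nM on the same read-out. These two numbers lie within the usual scatter of each other, so compound 2 stands level with compound 1 and neither can be ranked above the other.

Compound 3 (`ClC1=C(c2nnc(-c3cccc(I)c3)o2)CCCc2ccccc21`) differs from compound 2 in one place (iodo in place of hydrogen on an aromatic carbon): iodo in place of hydrogen on an aromatic carbon, so that phenyl becomes 3-iodophenyl. The two measured compounds do not differ in just one place, so the data give no direct guide to the size of this step. Only a small shift is therefore expected, leaning slightly toward lower numbers, which would mean stronger inhibition of growth. The estimate amounts to a 1.3-fold lower number from compound 2 to compound 3 (0.12 log units; within the scatter) in this assay and may well stay inside the scatter. Compound 3 is expected at about 1500 nM within an estimated range from 600 nM to 3800 nM on this measure.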

Compound 3, concentration for 50% growth inhibition: 4940 nM
Beside the measured number, compound 3's estimate is 3.3-fold (0.52 log units) below it; the whole stated range lies below it.
By their numbers in this assay, from the lowest: compounds 2, 1 and 3 (each within the scatter of the next, the first and the last beyond it).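

In this assay, among these compounds, the phenyl of compound 2 does not take an added iodo group without a price: the change to 3-iodophenyl brings a 2.5-fold higher number from compound 2 to compound 3 (0.40 log units; beyond the scatter), which is the first comparison here of two compounds differing in one place. This aromatic carbon, meta to a large group, is therefore not a silent spot, since a single heavy atom that adds no ring, no hydrogen-bond donor or acceptor and no net charge is enough to weaken inhibition of growth by a modest but readable amount. Nothing available explains why the number rises with this change.

Among the compounds shown here, with only one group tried at one place, it remains open whether this loss belongs to the iodo group itself or would follow any addition at this carbon, so a smaller fluoro group, a methoxy group or an amine could behave quite differently. On these data alone, it is also open whether iodo on another carbon of the same phenyl would shift the number in the same direction, or by a similar amount.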